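The source may hold more compounds than are shown below. What is called first, only, known or untested is meant among the compounds shown, and "the series" means these compounds.

Measured so far:
compound 1 `CCNC(=O)N1CCN(C(=S)SCc2cn(Cc3ccc(F)cc3)nn2)CC1` gives 3660 nM
compound 2 `CC(C)NC(=O)N1CCN(C(=S)SCc2cn(Cc3ccc(F)cc3)nn2)CC1` gives 1660 nM
compound 3 `CCNC(=O)N1CCN(C(=S)SCc2cn(Cc3cc(OC)c(OC)c(OC)c3)nn2)CC1` gives > 128000 nM

In a functional assay on MCF7 cells (Homo sapiens) for cytotoxicity, read by MTT assay, with a stated time of 72 h (a higher number here means a weaker inhibitor, a lower number a stronger inhibitor), compound 1 gives 3660 nM and compound 2 gives 1660 nM. The change between them is methyl in place of hydrogen on a saturated chain carbon bound to an amide-type nitrogen and a saturated chain carbon, and it made a 2.2-fold lower number from compound 1 to compound 2 (0.34 log units; beyond the scatter).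

Compound 3 stands in this assay at > 128000 nM, which is a limit of the assay and not a number. How the core of compound 3 differs from the core of compound 1 is not broken down here.

Compound 4 `COc1cc(Cn2cc(CSC(=S)N3CCN(C(=O)NC(C)C)CC3)nn2)cc(OC)c1OC` is not yet measured. It differs from compound 3 by methyl in place of hydrogen on a saturated chain carbon bound to an amide-type nitrogen and a saturated chain carbon, the same change that took compound 1 to compound 2, at the same place. Beside the earlier step, the step from compound 3 to compound 4 in this assay is expected to be of similar size, but it starts from a compound that sits at the limit of > 128000 nM in this assay, at which 1 of the 3 values shown sits, so a second limit is the most likely outcome. The expected step from compound 3 to compound 4 is an at least 1.1-fold lower number from compound 3 to compound 4 (0.06 log units; that floor lies within the scatter). Compound 4 is estimated at 110000 nM, with a range from 40000 nM to 300000 nM.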

Compound 4, half-maximal inhibitory concentration: > 128000 nM
Compound 4: a limit, no number (the forecaster's own chance of this, stated with the estimate: 70%); middle value at least 1.1-fold (0.06 log units) away from the limit.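

Compound 3 and compound 4 both sit at a limit and not at a number in this assay, so no step between them can be read: the limit of > 128000 nM in this assay, at which 2 of the 4 values shown sit.

The compounds shown leave open whether the change from ethyl to isopropyl has any effect on the core of compound 3, and where compound 3 and compound 4 truly stand.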